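The source may hold more compounds than are shown below. What is called first, only, known or untested is meant among the compounds shown, and "the series" means these compounds.

In an assay on HL-60 cells for agonist activity at N-formyl peptide receptor 3 (Homo sapiens), read by calcium flux (a higher number here means that more compound is needed for the effect, a lower number that less compound is needed), compound 1 `Cc1cc(N)c(=O)n(CC(=O)Nc2ccc(Br)cc2)n1` gives > 50000 nM, which is a limit of the assay and not a number. Compound 2 `COc1ccc(Nc2cc(C)nn(CC(=O)Nc3ccc(Br)cc3)c2=O)cc1` gives > 50000 nM, again only a limit. Compound 3 `COc1cccc(C(=O)Nc2cc(C)nn(CC(=O)Nc3ccc(Br)cc3)c2=O)c1` likewise gives > 50000 nM, a limit and nothing more. The measured steps therefore read as a step that the two limits leave unreadable from compound 1 to compound 2, a step that the two limits leave unreadable from compound 1 to compound 3 and a step that the two limits leave unreadable from compound 2 to compound 3, none of them readable in size because of the limit of > 50000 nM in this assay, at which 3 of the 3 values shown sit. Compound 4 `Cc1cc(NC(=O)c2ccc(Br)cc2)c(=O)n(CC(=O)Nc2ccc(Br)cc2)n1` differs from compound 3 by 4-bromophenyl in place of 3-methoxyphenyl on a carbonyl carbon. Among the compounds with values here, no measured step bears usefully on this change, so the three limits are the only guide. The estimate for compound 4 is 60000 nM, with a range from 15000 nM to 250000 nM. The expected step that the limit leaves unreadable from compound 3 to compound 4 is thus none beyond the scatter, and the assay would most likely again report only a limit.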

Compound 4, half-maximal effective concentration: > 50000 nM
Compound 4: only a limit was reported; the forecaster's own chance of this, stated with the estimate: 85%; the middle value lies beyond the limit too.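

Within the data shown here, compound 4 gives > 50000 nM, again only a limit, so no step from compound 1, compound 2 or compound 3 to compound 4 can be read in size: the limit of > 50000 nM in this assay, at which 4 of the 4 values shown sit. The compounds shown leave open which change to the shared core, if any, would give a readable value in this assay.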